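A few compounds are considered here, and "the series" means these few. Any claim that something is new, unique, unknown or untested is made for them only; others in the source may bear on it.

In a functional assay on MDA-MB-231 cells (Homo sapiens) for antiproliferative activity, read by sulforhodamine B assay, with a stated time of 72 h (on this read-out higher numbers stand for weaker inhibition and lower numbers for stronger inhibition), two compounds that carry a shared core have been measured so far. Compound 1 `COc1cc(OC)c(/C=C2\CCC=CC2=O)c(OC)c1` gives 5070 nM, and compound 2 `Cn1cc(/C=C2\CCC=CC2=O)c2ccccc21` gives 3370 nM. These two values lie within the usual scatter of each other, so the numbers do not separate compound 2 from compound 1. The next compound, compound 3 `CC(=O)n1cc(/C=C2\CCC=CC2=O)c2ccccc21`, keeps the structure of compound 2 except for one change, acetyl in place of methyl on an aromatic nitrogen. For the measured compounds named here, no measured pair shows a change at this place, so the data give no direction for it, and any expectation remains uncertain. The estimated step, a 1.1-fold lower number from compound 2 to compound 3 (0.05 log units; within the scatter), is expected to stay within the scatter. For compound 3, the expected value in this assay is 3000 nM, with an estimated range from 900 nM to 10000 nM.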

Compound 3, half-maximal inhibitory concentration: 930 nM
Compound 3: the middle estimate sits 3.2-fold (0.51 log units) above what was measured; low and high end bracket the measured number.
By their numbers in this assay, from the lowest: compound 3; then compounds 2 and 1 (each within the scatter of the next).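

The aromatic nitrogen proves to be a place where the group matters in this assay: acetyl in place of methyl gives a 3.6-fold lower number from compound 2 to compound 3 (0.56 log units; beyond the scatter). For the compounds shown here, until now, no measured pair showed a change here, so this single step supplies the first direction at this position. The entering acetyl has more heavy atoms than methyl and a hydrogen-bond acceptor, but no available measurement explains why the number falls.

One step cannot tell whether the lower number goes with the carbonyl of the acetyl or with the longer group as a whole. As far as these compounds go, a plain hydrogen on this nitrogen, a longer ethyl chain, or a methanesulfonyl group in the same place could begin to separate those readings, and whether the step carries over to other cores also stays open.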